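Phenethyl for 4-Chlorophenyl: An Expected Dose

The compounds below may be only part of what the source reports. "The series", "measured", "known", "first", "only" and "open" are said of these compounds alone.

Compound 2 `CCCCCCOc1ccc(-n2cnnc2-c2ccc(Cl)cc2)cc1` carries a 4-chlorophenyl group on the shared core. Going by the values given here, in a functional assay on the whole organism (strain C57B/6) with Mus musculus as the target, in the maximal electroshock model (on this read-out higher numbers stand for an effect only at larger amounts of compound and lower numbers for an effect already at smaller amounts), compound 2 gives 19.7 mg/kg, the smaller of the two numbers recorded so far, yet within the scatter of its only neighbour, compound 1 `CCCCCCOc1ccc(-n2cnnc2CCCCC)cc1`, which in this assay gives 32.8 mg/kg. Among the compounds with values here, the single measured step, a 1.7-fold lower number from compound 1 to compound 2 (0.22 log units; within the scatter), exchanges pentyl for 4-chlorophenyl and does not rise beyond the scatter.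

Compound 3 `CCCCCCOc1ccc(-n2cnnc2CCc2ccccc2)cc1` has not yet been measured. Its difference from compound 2 is phenethyl in place of 4-chlorophenyl on an aromatic carbon. Within the data shown here, the one measured step bears on this change, because a 1.7-fold lower number from compound 1 to compound 2 (0.22 log units; within the scatter) also exchanges the group on this aromatic carbon and stayed within the scatter. Among the measured compounds shown here, with only that comparison available, no step beyond the scatter is expected in this assay in either direction. Compound 3 is therefore expected to give about 25 mg/kg, with a likely range from 12 mg/kg to 50 mg/kg. The step from compound 2 to compound 3 that this estimate implies is a 1.3-fold higher number from compound 2 to compound 3 (0.10 log units; within the scatter).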

Compound 3, dose for half-maximal effect: 27.4 mg/kg
Compound 3: middle estimate off by 1.1-fold (0.04 log units), on the low side, within the range that was stated.
By their numbers in this assay, from the lowest: compounds 2, 3 and 1 (each within the scatter of the next).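

In this assay, this aromatic carbon has now taken a third kind of group, and neither new step leaves the scatter: phenethyl for 4-chlorophenyl gives a 1.4-fold higher number from compound 2 to compound 3 (0.14 log units; within the scatter), while the exchange against the pentyl compound gives a 1.2-fold lower number from compound 1 to compound 3 (0.08 log units; within the scatter). Pentyl, 4-chlorophenyl and phenethyl therefore cannot be told apart on this read-out, whether the group has a six-membered aromatic ring of carbon only, as in compound 2 and compound 3, or none, as in compound 1, and the step from compound 2 to compound 3 also takes away the chlorine and brings in a saturated chain in one change, so the two cannot be separated. No measurement available here offers an explanation for these numbers.

Going by these compounds, all three groups on this carbon are free of hydrogen-bond donors and acceptors and carry no net charge, so it remains open whether an amine or a carboxylic acid there would move the dose beyond the scatter. On these data alone, it is equally open whether a phenyl ring on a longer chain would do so, or whether the chlorine would matter on the phenethyl group.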